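This account rests on a few compounds, and the source may have more. Where it says the series, first, only, none or still open, it means among the compounds named here.

Measured so far:
compound 1, `COc1ccc(F)cc1CNCCCNc1ccnc2cc(Oc3ccc(F)cc3)ccc12`, 6600 nM
compound 2, `COc1ccc(-c2ccc3c(NCCCNCc4cc(F)ccc4OC)ccnc3c2)cc1`, 5960 nM

Both compounds were tested in an ADME assay on HepG2 cells (Homo sapiens) for cytotoxicity, read by luminescence, CellTiter-Glo and ATP content, with a stated time of 72 h; on this read-out higher numbers stand for an effect only at larger amounts of compound and lower numbers for an effect already at smaller amounts. Compound 1 gives 6600 nM and compound 2 gives 5960 nM. Within the data shown here, compound 2 thus stands alongside compound 1 rather than apart from it: the only step measured, a 1.1-fold lower number from compound 1 to compound 2 (0.04 log units; within the scatter), is within the scatter, so the two numbers cannot be told apart.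

Compound 3 is `COc1ccc(F)cc1CNCCCNc1ccnc2cc(Oc3ccccc3OC)ccc12`. It differs from compound 2 in one place: 2-methoxyphenoxy in place of 4-methoxyphenyl on an aromatic carbon.

Among the measured compounds shown here, only one measured step bears on this change, the one from compound 1 to compound 2, in which a group on the same aromatic carbon was exchanged and the number moved by a 1.1-fold lower number from compound 1 to compound 2 (0.04 log units; within the scatter), within the scatter. Compound 1 already carries a group of the phenoxy type at this place, and it gives a number close to that of compound 2. The expectation for this assay is therefore a step of a 1.1-fold higher number from compound 2 to compound 3 (0.04 log units; within the scatter), that is none beyond the scatter. Compound 3 is estimated at 6500 nM, within a range from 3000 nM to 14000 nM.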

Compound 3, half-maximal effective concentration: 6400 nM
Compound 3: the middle estimate sits 1.0-fold (0.01 log units) above what was measured, and the stated range covers the measured number.
By their numbers in this assay, from the lowest: compounds 2, 3 and 1 (each within the scatter of the next).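

In this assay, the exchange of 4-methoxyphenyl for 2-methoxyphenoxy gives a 1.1-fold higher number from compound 2 to compound 3 (0.03 log units; within the scatter), so adding a hydrogen-bond acceptor and a heavy atom to the group on this aromatic carbon leaves no readable mark on the number. Within the phenoxy type, 2-methoxyphenyl in place of 4-fluorophenyl on the oxygen gives a 1.0-fold lower number from compound 1 to compound 3 (0.01 log units; within the scatter), which shows that a different substituent, at a different place on that outer ring, also stays within the scatter, and all three groups now tried here give numbers that cannot be told apart. No measurement at hand explains why these numbers stay together.

All three groups carry a six-membered aromatic ring of carbon only, so the compounds shown leave open whether the number would hold with something quite different on this carbon, such as a carboxylic acid, a simple amine or a plain methyl group. They also cannot tell whether the same calm would hold if the shared core or its side chain were changed, for example to a longer chain.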